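Swapping Furan for Thiophene on the Amine Substituent

The source may hold more compounds than are shown below. What is called first, only, known or untested is meant among the compounds shown, and "the series" means these compounds.

Compound 3 `NS(=O)(=O)OC[C@@H]1C[C@@H](n2nnc3c(NCc4ccco4)ncnc32)C[C@@H]1O` gives 30.6 nM in an assay on a protein complex for inhibition of NEDD8 activating enzyme (Homo sapiens), read by HTRF, with a stated time of 2 h, in the presence of a further agent that is not named here (on this read-out lower numbers stand for stronger inhibition and higher numbers for weaker inhibition), the highest number of the three measured and so the weakest inhibition. Compound 1 `NS(=O)(=O)OC[C@@H]1C[C@@H](n2nnc3c(N[C@H]4CCc5ccccc54)ncnc32)C[C@@H]1O` gives 0.21 nM and compound 2 `NS(=O)(=O)OC[C@@H]1C[C@@H](n2nnc3c(NCc4ccccc4F)ncnc32)C[C@@H]1O` gives 6.11 nM in this assay. Compound 4 `NS(=O)(=O)OC[C@@H]1C[C@@H](n2nnc3c(NCc4cccs4)ncnc32)C[C@@H]1O` differs from compound 3 in one place: thiophen-2-yl in place of furan-2-yl on a saturated chain carbon bound to a nitrogen on an aromatic ring. For the measured compounds named here, no measured step exchanges one of these five-membered rings for the other, so no direct guide exists. The nearest comparison is a 5.0-fold higher number from compound 2 to compound 3 (0.70 log units; beyond the scatter), where furan-2-yl gave a modestly higher number than 2-fluorophenyl; the steps of a 29-fold higher number from compound 1 to compound 2 (1.46 log units; beyond the scatter) and a 150-fold higher number from compound 1 to compound 3 (2.16 log units; beyond the scatter) replace the whole group and bear only loosely. A small shift toward a lower number in this assay is expected, a 2.0-fold lower number from compound 3 to compound 4 (0.31 log units; beyond the scatter). Compound 4 is estimated at 15 nM, within a range from 5 nM to 45 nM.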

Compound 4, half-maximal inhibitory concentration: 15.9 nM
Beside the measured number, compound 4's estimate is 1.1-fold (0.03 log units) below it; measured number inside the range.
By their numbers in this assay, from the lowest: compound 1; then compound 2; then compounds 4 and 3 (each within the scatter of the next).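

In this assay, thiophen-2-yl and furan-2-yl on this saturated chain carbon cannot be told apart (a 1.9-fold lower number from compound 3 to compound 4 (0.28 log units; within the scatter)), so exchanging the ring oxygen for sulfur has no measurable effect here. The larger gaps remain, with compound 4 weaker than the compounds carrying other groups (a 2.6-fold higher number from compound 2 to compound 4 (0.42 log units; beyond the scatter); a 76-fold higher number from compound 1 to compound 4 (1.88 log units; beyond the scatter)). Nothing available explains these results.

The compounds shown leave open how a pyridin-2-yl or thiazol-2-yl group would read at this place. They also leave open whether a methyl group on the thiophene ring would move the number toward that of compound 1.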